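Nitro Substitution Compared Across Two Related Cores

The compounds below may be only part of what the source reports. "The series", "measured", "known", "first", "only" and "open" are said of these compounds alone.

Compound 1 `O=[N+]([O-])c1ccc(COc2cccc(Nc3ncnc4cc5c(cc34)OCCOCCO5)c2)cc1`: 42400 nM
Compound 2 `c1ccc(COc2cccc(Nc3ncnc4cc5c(cc34)OCCOCCO5)c2)cc1`: 40900 nM
Compound 3 `c1ccc(COc2cccc(Nc3ncnc4cc5c(cc34)OCCOCCOCCO5)c2)cc1`: > 100000 nM, a limit of the assay

In a functional assay on MCF7 cells (Homo sapiens) for antiproliferative activity, read by MTT assay, with a stated time of 72 h (on this read-out lower numbers stand for stronger inhibition and higher numbers for weaker inhibition), compound 2 gives 40900 nM. Compound 1 carries nitro in place of hydrogen on an aromatic carbon and gives 42400 nM in this assay, so that a 1.0-fold higher number from compound 2 to compound 1 (0.02 log units; within the scatter). Compound 3 reaches only the limit of > 100000 nM in this assay, at which 1 of the 3 values shown sits, in this assay. The difference between the core of compound 2 and the core of compound 3 is not broken down here. Compound 4 `O=[N+]([O-])c1ccc(COc2cccc(Nc3ncnc4cc5c(cc34)OCCOCCOCCO5)c2)cc1` is not yet measured; it differs from compound 3 by nitro in place of hydrogen on an aromatic carbon, the same change as from compound 2 to compound 1, at the same place. Because the measured step of a 1.0-fold higher number from compound 2 to compound 1 (0.02 log units; within the scatter) lies within the scatter, the step that the limit leaves unreadable from compound 3 to compound 4 is expected to be of similar size, and, because compound 3 sits at the limit of > 100000 nM in this assay, at which 1 of the 3 values shown sits, compound 4 is expected most often to return a limit as well. Compound 4 is estimated at 130000 nM, between 50000 nM and 350000 nM.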

Compound 4, half-maximal inhibitory concentration: > 100000 nM
Compound 4 ended at the assay's limit; the forecaster's own chance of this, stated with the estimate: 75%; the middle value does not contradict the limit.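

No step can be read from compound 3 to compound 4, since both return only a limit: the limit of > 100000 nM in this assay, at which 2 of the 4 values shown sit. The compounds shown leave open whether nitro in place of hydrogen changes anything on the core of compound 3.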